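Aryl urea series: step from compound 2 to compound 4

The source may report more compounds than this note shows. Statements on the series, on what has been measured and on what is new or still open speak of the compounds shown alone.

Measured so far in a functional assay on a cell-free system (plasma) with sterol O-acyltransferase, Soat (Rattus norvegicus) as the target; a higher number here means that more compound is needed for the effect, a lower number that less compound is needed:
- compound 1, `Cc1cc(C)c(NC(=O)N(Cc2cc(-c3ccccc3)on2)C2CCCCCC2)c(C)c1`, gives > 1 mg/kg, which is a limit of the assay.
- compound 2, `Cc1cc(C)c(NC(=O)N(Cc2ccc(-c3nnc(C)o3)cc2)C2CCCCCC2)c(C)c1`, gives > 0.32 mg/kg, again a limit.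
- compound 3, `CSc1cc(C)nc(SC)c1NC(=O)N(Cc1ccccc1)Cc1cccc(-c2ccnn2C)c1`, gives < 1 mg/kg, also a limit.

Within the data shown here, compound 2 therefore stands on a limit rather than a number, and the two further values shown are limits as well (the limit of < 1 mg/kg in this assay, at which 1 of the 3 values shown sits, (the limit of > 0.32 mg/kg in this assay, at which 1 of the 3 values shown sits), (the limit of > 1 mg/kg in this assay, at which 1 of the 3 values shown sits)), so no measured step exists in this assay. Compound 4, `Cc1cc(C)c(NC(=O)N(Cc2ccc(-c3ccsc3)cc2)C2CCCCCC2)c(C)c1`, differs from compound 2 by thiophen-3-yl in place of 5-methyl-1,3,4-oxadiazol-2-yl on an aromatic carbon. Among the measured compounds shown here, with no measured step to lean on, the change from compound 2 to compound 4 is expected to stay near the scatter, a step that the limit leaves unreadable from compound 2 to compound 4. For compound 4 the expected value in this assay is 1 mg/kg, within 0.3 mg/kg to 3 mg/kg.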

Compound 4, dose for half-maximal effect: 0.51 mg/kg
For compound 4 the middle estimate is 2.0-fold (0.29 log units) above the measured one; low and high end bracket the measured number.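

The step between compound 2 and compound 4 cannot be read in this assay, because compound 2 stands on a limit, not a number: the limit of > 0.32 mg/kg in this assay, at which 1 of the 4 values shown sits.

On these data alone, whether thiophen-3-yl in place of 5-methyl-1,3,4-oxadiazol-2-yl changes the required dose, and in which direction, stays open.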